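The source may report more compounds than this note shows. Statements on the series, on what has been measured and on what is new or still open speak of the compounds shown alone.

Measured in a functional assay on B16-F0 cells (Mus musculus) for inhibition, read by CCK-8 assay, with a stated time of 48 h; a higher number here means a weaker inhibitor, a lower number a stronger inhibitor:
compound 1 `COc1cc(-c2ccnc3cc(-c4cn(CO)c5ccccc45)nn23)cc(OC)c1OC` gives 93 nM
compound 2 `COc1cc(-c2ccnc3cc(-c4ccc(Cl)cc4)nn23)cc(OC)c1OC` gives 4090 nM
compound 3 `C=Cc1ccc(-c2cc3nccc(-c4cc(OC)c(OC)c(OC)c4)n3n2)cc1` gives 788 nM

Compound 1 has the lowest number of the three, and its gaps to compound 3 and compound 2 lie beyond the scatter. Compound 4 `COc1cc(-c2ccnc3cc(-c4cn(C(=O)OC(C)(C)C)c5ccccc45)nn23)cc(OC)c1OC` differs from compound 1 by tert-butoxycarbonyl in place of hydroxymethyl on an aromatic nitrogen. Among the measured compounds shown here, no step at this nitrogen has been measured. For the measured compounds named here, the only measured step, a 5.2-fold lower number from compound 2 to compound 3 (0.72 log units; beyond the scatter), swaps chloro for vinyl on an aromatic carbon elsewhere, so it serves only as a loose guide to size. A modest rise in the number is expected, since compound 1 starts from the lowest value, 93 nM, and the uncertainty is wide. The expected change is a 3.0-fold higher number from compound 1 to compound 4 (0.48 log units; beyond the scatter). For compound 4 the estimated value is 280 nM, with an expected range from 70 nM to 1100 nM.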

Compound 4, half-maximal inhibitory concentration: 3070 nM
Compound 4: middle estimate off by 11-fold (1.04 log units), on the low side; measured number above the stated range.
By their numbers in this assay, from the lowest: compound 1; then compound 3; then compounds 4 and 2 (each within the scatter of the next).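

In this assay, the aromatic nitrogen of the shared core proves far from indifferent to what it carries: tert-butoxycarbonyl in place of hydroxymethyl gives a 33-fold higher number from compound 1 to compound 4 (1.52 log units; beyond the scatter). This first measured step at this nitrogen shows that the low number of compound 1 is lost on this exchange, in which the entering group has more heavy atoms and no hydrogen-bond donor. Nothing available accounts for the rise. The compounds shown leave open which of these differences matters, and whether a methyl group or an aminoethyl chain on this nitrogen would keep the number near that of compound 1.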